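The source may report more compounds than this note shows. Statements on the series, on what has been measured and on what is new or still open speak of the compounds shown alone.

Measured so far in an ADME assay on MT4 cells (Homo sapiens) for cytotoxicity, read by MTT assay, with a stated time of 5 days; on this read-out higher numbers stand for lower toxicity in this test and lower numbers for higher toxicity in this test:
compound 1 `Cc1cc(C#N)cc(C)c1Oc1nc(Nc2ccc(C#N)cc2)ncc1-c1ccsc1`, 3920 nM;
compound 2 `Cc1cc(C#N)cc(C)c1Oc1nc(Nc2ccc(C#N)cc2)ncc1-c1cccnc1`, 13500 nM;
compound 3 `Cc1cc(C#N)cc(C)c1Oc1nc(Nc2ccc(C#N)cc2)ncc1-c1ccc(N)cc1`, 310 nM.

Compound 3 stands at the lowest number of the three in this assay, and both steps leading to it lie beyond the scatter: a 13-fold lower number from compound 1 to compound 3 (1.10 log units; beyond the scatter) and a 44-fold lower number from compound 2 to compound 3 (1.64 log units; beyond the scatter). The remaining step, a 3.4-fold higher number from compound 1 to compound 2 (0.54 log units; beyond the scatter), is modest. All three measured compounds share the same core and differ only in the group on the aromatic carbon ortho to the 4-cyano-2,6-dimethylphenoxy group.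

Compound 4 `Cc1cc(C#N)cc(C)c1Oc1nc(Nc2ccc(C#N)cc2)ncc1-c1ccc2ccccc2c1` is the next member of the series, differing from compound 3 by naphthalen-2-yl in place of 4-aminophenyl on an aromatic carbon. Among the measured compounds shown here, no measured step introduces naphthalen-2-yl, so the bearing steps are those that remove the 4-aminophenyl group, read in reverse: from compound 3 to compound 1 and from compound 3 to compound 2, both large. The two groups without a hydrogen-bond donor, thiophen-3-yl and pyridin-3-yl, gave higher numbers than 4-aminophenyl; naphthalen-2-yl likewise carries no donor or acceptor. On that basis a higher number is expected for compound 4, with the step of a 6.5-fold higher number from compound 3 to compound 4 (0.81 log units; beyond the scatter) estimated to be large. For compound 4 the estimate in this assay is 2000 nM, with a range from 500 nM to 8000 nM.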

Compound 4, half-maximal cytotoxic concentration: 8460 nM
The estimate for compound 4 lay 4.2-fold (0.63 log units) below the measured number; the whole stated range lies below it.
By their numbers in this assay, from the lowest: compound 3; then compound 1; then compounds 4 and 2 (each within the scatter of the next).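

Replacing 4-aminophenyl (7 heavy atoms) with the larger naphthalen-2-yl (10 heavy atoms) gives a 27-fold higher number from compound 3 to compound 4 (1.44 log units; beyond the scatter) in this assay, so a larger aromatic group on this carbon does not by itself bring the number down. The step from pyridin-3-yl to naphthalen-2-yl is a 1.6-fold lower number from compound 2 to compound 4 (0.20 log units; within the scatter) and the step from thiophen-3-yl to naphthalen-2-yl is a 2.2-fold higher number from compound 1 to compound 4 (0.33 log units; beyond the scatter); among the four compounds, 4-aminophenyl alone is separated from the others by large steps, while the other three groups differ by modest steps or lie within the scatter. No measurement at hand accounts for the separate standing of compound 3.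

The compounds shown leave open whether the amine itself sets the low number of compound 3, a question that an unsubstituted phenyl or a 4-hydroxyphenyl on this carbon would address. Also open, from the compounds shown here alone, is whether a dimethylamino or aminomethyl group at the same place on the phenyl ring would keep that low number, and how a saturated ring such as morpholine would compare with the aromatic groups.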